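Para-methyl on the benzamide of a shared core

The source may report more compounds than this note shows. Statements on the series, on what has been measured and on what is new or still open speak of the compounds shown alone.

Compound 3 `O=C(CSc1cccc(O)c1)Nc1ccc2nc(NC(=O)c3ccccc3)sc2c1` gives the highest number of the three measured in a functional assay on HCT-116 cells (Homo sapiens) for antiproliferative activity, read by MTT assay, with a stated time of 72 h (on this read-out higher numbers stand for weaker inhibition and lower numbers for stronger inhibition), at 41000 nM. Compound 1 `O=C(CSc1cccc(O)c1)Nc1ccc2nc(NC(=O)c3ccc(C(F)(F)F)cc3)sc2c1` gives 510 nM in this assay, and compound 2 `Cc1cc(C)cc(C(=O)Nc2nc3ccc(NC(=O)CSc4cccc(O)c4)cc3s2)c1` gives 5130 nM. The steps of an 80-fold higher number from compound 1 to compound 3 (1.91 log units; beyond the scatter) and an 8.0-fold higher number from compound 2 to compound 3 (0.90 log units; beyond the scatter) both show that a group on the six-membered aromatic ring of carbon only, in place of hydrogen, lowers the number.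

Compound 4 `Cc1ccc(C(=O)Nc2nc3ccc(NC(=O)CSc4cccc(O)c4)cc3s2)cc1` differs from compound 3 in one place: methyl in place of hydrogen on an aromatic carbon. Going by the values given here, no measured step puts a single methyl on this ring, so the size of the effect must be taken from the two steps above, which rested on trifluoromethyl and on 3,5-dimethyl. A methyl in place of hydrogen is expected to lower the number in this assay, with a step of a 5.1-fold lower number from compound 3 to compound 4 (0.71 log units; beyond the scatter) that is estimated to fall between the sizes of those two measured steps. Compound 4 is therefore expected to give about 8000 nM, within a range of 2000 nM to 30000 nM.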

Compound 4, half-maximal inhibitory concentration: 7730 nM
Estimate against measurement, compound 4: 1.0-fold (0.01 log units) above; the range from low to high includes it.
By their numbers in this assay, from the lowest: compound 1; then compounds 2 and 4 (each within the scatter of the next); then compound 3.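

In this assay, going by these compounds alone, a single methyl, para to a large group, is enough on its own to lower the number, with a 5.3-fold lower number from compound 3 to compound 4 (0.72 log units; beyond the scatter) as the step, whereas the earlier compounds showed this only for trifluoromethyl and for two methyl groups. A second methyl adds nothing that can be read, since 4-methylphenyl in place of 3,5-dimethylphenyl gives a 1.5-fold higher number from compound 2 to compound 4 (0.18 log units; within the scatter) as its step. Trifluoromethyl at this place still stands clearly apart from methyl, with a 15-fold higher number from compound 1 to compound 4 (1.18 log units; beyond the scatter) as the step.

The data shown offer no evidence that would explain these differences. Also open, on these data alone, is where a chlorine atom, a methoxy group or an amine at this place would fall relative to methyl and trifluoromethyl.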